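Shorter chain at the saturated carbon of the core

The compounds below may be only part of what the source reports. "The series", "measured", "known", "first", "only" and "open" are said of these compounds alone.

Measured so far in a functional assay on HeLa cells (Homo sapiens) for cytotoxicity, read by WST assay, with a stated time of 48 h; a lower number here means a stronger inhibitor, a higher number a weaker inhibitor: compound 1 `COc1cc(C(c2ccc(O)c(OC)c2)[C@H](CC(C)C)C(C)C)ccc1O` gives 8200 nM; compound 2 `COC[C@H](C)[C@H](C)C(c1ccc(O)c(OC)c1)c1ccc(O)c(OC)c1` gives 72000 nM. Compound 3 `COc1ccc(C(c2ccc(OC)c(OC)c2)[C@@H](C)[C@@H](C)CO)cc1OC` reports only a limit of the assay, > 100000 nM.

Compound 1 holds the lowest of the two numbers; the nearest is an 8.8-fold higher number from compound 1 to compound 2 (0.94 log units; beyond the scatter). Compound 4 `COc1cc(C(c2ccc(O)c(OC)c2)[C@@H](C)C(C)C)ccc1O` differs from compound 1 by 1,2-dimethylpropyl in place of 1-isopropyl-3-methylbutyl on a saturated chain carbon bound to two aromatic carbons. For the measured compounds named here, the one measured step at this position, an 8.8-fold higher number from compound 1 to compound 2 (0.94 log units; beyond the scatter), also replaces the larger chain with a smaller one, 2-(methoxymethyl)-1-methylpropyl, and weakens inhibition. Compound 4 shrinks the chain to 1,2-dimethylpropyl, so a weakening in this assay is expected, but a smaller one, estimated as a 2.4-fold higher number from compound 1 to compound 4 (0.39 log units; beyond the scatter). Compound 4 is therefore expected near 20000 nM, with a range of 8000 nM to 60000 nM.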

Compound 4, half-maximal inhibitory concentration: 19000 nM
Compound 4: the middle estimate sits 1.1-fold (0.02 log units) above what was measured; low and high end bracket the measured number.
By their numbers in this assay, from the lowest: compound 1; then compound 4; then compound 2. At a limit, above all of these: compound 3.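

In this assay, shortening the chain to 1,2-dimethylpropyl costs little: the change gives a 2.3-fold higher number from compound 1 to compound 4 (0.36 log units; beyond the scatter) and leaves this position tolerant of a smaller chain. Hydrogen in place of methoxy on a saturated chain carbon, four bonds along the chain from two aromatic carbons, gives a 3.8-fold lower number from compound 2 to compound 4 (0.58 log units; beyond the scatter) and so shows that part of the earlier loss follows the methoxy, not chain size alone.

Going by these compounds, whether an amine or a carboxylic acid at that chain end would behave like methoxy, or a longer chain would lower the number further, remains open. Nothing shown gives a reason for either step.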